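The compounds below may be only part of what the source reports. "The series", "measured", "known", "first", "only" and "open" are said of these compounds alone.

Among the measured compounds shown here, compound 3 `CSc1nc2snc(C)c2n1[C@H]1C[C@H](O)[C@@H](CO)O1` is the one member of this set that gives a number in a functional assay on HFF cells (Homo sapiens) for inhibition; on this read-out higher numbers stand for weaker inhibition and lower numbers for stronger inhibition: compound 3 gives 32000 nM. Compound 1 `Cc1nsc2c1ncn2[C@H]1C[C@H](O)[C@@H](CO)O1` is reported only as a limit, and in this assay compound 1 gives > 100000 nM. Compound 2 `Cc1nsc2ncn([C@H]3C[C@H](O)[C@@H](CO)O3)c12` is likewise reported as a limit, and in this assay compound 2 gives > 100000 nM. For the measured compounds named here, the one measured step is an at least 3.1-fold lower number from compound 2 to compound 3 (0.49 log units; beyond the scatter), the only step in the set that ends at a number rather than at the limit of > 100000 nM in this assay, at which 2 of the 3 values shown sit.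

Compound 4 `CSc1nc2sncc2n1[C@H]1C[C@H](O)[C@@H](CO)O1` differs from compound 3 by hydrogen in place of methyl on an aromatic carbon. Going by the values given here, no measured step touches this methyl: the only step recorded concerns the methylsulfanyl group, and both compounds that lack that group sit at the limit. The change is therefore hard to weigh from these data. A step of no more than modest size in this assay would be expected, possibly none beyond the scatter, with a weakening more likely than a gain since compound 3 itself gives only 32000 nM. That compound 4 might return no number at all in this assay cannot be ruled out. Compound 4 is expected to give about 50000 nM in this assay, between 20000 nM and 150000 nM, which corresponds to an expected 1.6-fold higher number from compound 3 to compound 4 (0.19 log units; within the scatter).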

Compound 4, half-maximal inhibitory concentration: 15000 nM
Estimate against measurement, compound 4: 3.3-fold (0.52 log units) above; measured number outside the range, below it.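

In this assay, hydrogen in place of methyl on this aromatic carbon, next to the ring nitrogen, gives a 2.1-fold lower number from compound 3 to compound 4 (0.33 log units; beyond the scatter), a modest step beyond the scatter. The methyl is therefore not required for a measurable number in this pair, and its removal goes with stronger inhibition. Among the compounds shown here, this is the first reading at this position, as the only earlier step concerned the methylsulfanyl group, and the methyl-bearing compounds without that group gave no number to compare: the limit of > 100000 nM in this assay, at which 2 of the 4 values shown sit. The finding rests on a single pair of compounds that both carry methylsulfanyl, so it describes this change only in that setting.

The compounds shown have only methyl or hydrogen on this carbon, which leaves open what an ethyl group, a chlorine atom or an amine would do there. Also open, from the compounds shown here alone, is whether a longer chain on the sulfur, such as ethylsulfanyl in place of methylsulfanyl, or an amine in place of that group, would move the number further on the core of compound 4.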